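The source may report more compounds than this note shows. Statements on the series, on what has been measured and on what is new or still open speak of the compounds shown alone.

Three compounds have been measured in a functional assay on HCT-8 cells (Homo sapiens) for antiproliferative activity, read by MTT assay, with a stated time of 48 h (a higher number here means a weaker inhibitor, a lower number a stronger inhibitor), so far:

Compound 1 `COc1ccc(C(=O)c2ccc3c(c2)C=CC(C)(C)O3)c(NC(=O)CN)c1` at 490 nM
Compound 2 `CNCC(=O)Nc1cc(OC)ccc1C(=O)c1ccc(OC)c2c1OC(C)(C)C=C2` at 740 nM
Compound 3 `CNCC(=O)Nc1cc(OC)ccc1C(=O)c1ccc(OC)c2c1C=CC(C)(C)O2` at 3460 nM

Compound 1 sits at the low end of this small set, within the scatter of compound 2, while compound 3 has a number beyond the scatter from compound 1. The next compound to be tested is compound 4 `COc1ccc(C(=O)c2ccc3c(c2)C=CC(C)(C)O3)c(NC(=O)CN(C)C)c1`, which keeps the core of compound 1 and changes a single group. It carries dimethylamino in place of amino on a saturated chain carbon bound to a carbonyl carbon in the structure.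

For the measured compounds named here, no measured pair isolates this change, so the expectation is a loose one. A modest move toward a higher number in this assay is expected, one that may not clear the scatter. The estimated change is a 1.6-fold higher number from compound 1 to compound 4 (0.21 log units; within the scatter) in this read-out. For compound 4 the expected value is 800 nM with an estimated range from 250 nM to 2500 nM in this assay.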

Compound 4, half-maximal inhibitory concentration: 2420 nM
For compound 4 the middle estimate is 3.0-fold (0.48 log units) below the measured one; low and high end bracket the measured number.
By their numbers in this assay, from the lowest: compounds 1 and 2 (each within the scatter of the next); then compounds 4 and 3 (each within the scatter of the next).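

In this assay, for the compounds shown here, dimethylamino in place of amino on a saturated chain carbon bound to a carbonyl carbon gives a 4.9-fold higher number from compound 1 to compound 4 (0.69 log units; beyond the scatter) and provides the first reading of this change with the rest of the structure held constant. The earlier compounds shown here differ from one another in more than one place, so they could not isolate this position, which now proves sensitive to this replacement. No measurement available here accounts for the step.

On these data alone, it remains open whether methylamino on the core of compound 1 would read nearer to amino or to dimethylamino, and how a pyrrolidine or a longer chain would fare at this place. As far as these compounds go, whether the same change would give a similar step on other cores also remains unknown.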